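Swapping the group on the sulfonyl sulfur of compound 3

The source may report more compounds than this note shows. Statements on the series, on what has been measured and on what is new or still open speak of the compounds shown alone.

Three compounds sharing one core have numbers so far in an ADME assay on microsomes (Homo sapiens) for metabolic stability (on this read-out lower numbers stand for slow clearance and higher numbers for fast clearance), as follows:

- compound 1 `Cc1cc(C(F)(F)F)c2cccc(OCc3c(Cl)ccc(S(=O)(=O)N4CCC[C@H]4CO)c3Cl)c2n1` gives 250 mL/min/kg
- compound 2 `COC[C@@H]1CCCN1S(=O)(=O)c1ccc(Cl)c(COc2cccc3c(C(F)(F)F)cc(C)nc23)c1Cl` gives 450 mL/min/kg
- compound 3 `Cc1cc(C(F)(F)F)c2cccc(OCc3c(Cl)ccc(S(=O)(=O)N4CC[C@@H](N(C)C)C4)c3Cl)c2n1` gives 167 mL/min/kg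

Two steps place compound 3. There is a 2.7-fold lower number from compound 2 to compound 3 (0.43 log units; beyond the scatter) and there is a 1.5-fold lower number from compound 1 to compound 3 (0.18 log units; within the scatter) so it is set apart from one of its two neighbours only.

Compound 4 `Cc1cc(C(F)(F)F)c2cccc(OCc3c(Cl)ccc(S(=O)(=O)N4CCC(CCO)CC4)c3Cl)c2n1` differs from compound 3 on a sulfonyl sulfur whose other neighbour is an aromatic carbon, and 4-(2-hydroxyethyl)piperidin-1-yl in place of 3-(dimethylamino)pyrrolidin-1-yl on a sulfonyl sulfur is the whole of that difference. For the measured compounds named here, both steps above were swaps at this same place, one modest and one within the scatter, but neither brought in 4-(2-hydroxyethyl)piperidin-1-yl, and no measured compound carries it. The closest guide is compound 1 (250 mL/min/kg) whose 2-(hydroxymethyl)pyrrolidin-1-yl also holds a hydroxyl. Capping that hydroxyl gave a 1.8-fold higher number from compound 1 to compound 2 (0.26 log units; within the scatter) in a comparison that shows little.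

The expected step is a 1.5-fold higher number from compound 3 to compound 4 (0.18 log units; within the scatter) and so no change beyond the scatter is expected. In this assay the estimate for compound 4 is 250 mL/min/kg with an expected range from 120 mL/min/kg to 500 mL/min/kg until the measurement arrives.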

Compound 4, clearance: 367 mL/min/kg
Compound 4: the middle estimate sits 1.5-fold (0.17 log units) below what was measured; low and high end bracket the measured number.
By their numbers in this assay, from the lowest: compounds 3, 1, 4 and 2 (each within the scatter of the next, the first and the last beyond it).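

For the compounds shown here, at the sulfonyl sulfur, 4-(2-hydroxyethyl)piperidin-1-yl in place of 3-(dimethylamino)pyrrolidin-1-yl gives in this assay a 2.2-fold higher number from compound 3 to compound 4 (0.34 log units; beyond the scatter) and so compound 3, which had been set apart from only one of its neighbours, is now set apart from two of its three. The new group does not separate from either oxygen-bearing group on a five-membered ring, with a 1.5-fold higher number from compound 1 to compound 4 (0.17 log units; within the scatter) and a 1.2-fold lower number from compound 2 to compound 4 (0.09 log units; within the scatter) as the two steps, both within the scatter. Ring size and side chain change together in the step to compound 4 from compound 1, so this result shows that the two changes taken jointly leave the number unresolved from that of compound 1, but it cannot assign anything to either change alone.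

The compounds shown leave open whether the gap to compound 3 follows its dimethylamino group or its ring, a question that 4-(dimethylamino)piperidin-1-yl on the same sulfonyl sulfur would bear on, as would a carboxylic acid in place of the hydroxyl of the 2-hydroxyethyl chain. No measurement at hand accounts for any of these steps.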